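Swapping Pyridin-4-yl for 5-Carboxythiophen-2-yl: Expected Solubility

The source may hold more compounds than are shown below. What is called first, only, known or untested is meant among the compounds shown, and "the series" means these compounds.

Compound 1 `CCCCc1nc(C(C)(C)C)nc2nc(N)c(C#N)c(N)c12` gives 6000 nM
Compound 2 `CC(C)(C)c1nc(-c2nccs2)c2c(N)c(C#N)c(N)nc2n1` gives < 1500 nM as a limit
Compound 3 `CC(C)(C)c1nc(-c2ccncc2)c2c(N)c(C#N)c(N)nc2n1` gives 44000 nM

Compound 3 holds the highest number in a physicochemical assay for solubility, in phosphate buffer, with a stated time of 18 h (a lower number here means a less soluble compound, a higher number a more soluble compound), and compound 1 has the nearest number. The next change gives compound 4 `CC(C)(C)c1nc(-c2ccc(C(=O)O)s2)c2c(N)c(C#N)c(N)nc2n1` with 5-carboxythiophen-2-yl in place of pyridin-4-yl on an aromatic carbon and this is the same place that varied before. For the measured compounds named here, three measured steps bear on it: an at least 4.0-fold lower number from compound 1 to compound 2 (0.60 log units; beyond the scatter) and a 7.3-fold higher number from compound 1 to compound 3 (0.87 log units; beyond the scatter) and an at least 29-fold higher number from compound 2 to compound 3 (1.46 log units; beyond the scatter) in that order. They run both ways and none brings in 5-carboxythiophen-2-yl. No step beyond the scatter is therefore expected in this assay in either direction. The expected change is a 1.1-fold higher number from compound 3 to compound 4 (0.06 log units; within the scatter) as an estimate with wide uncertainty. Compound 4 is estimated at 50000 nM with an expected range from 8000 nM to 200000 nM in this assay here.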

Compound 4, solubility: > 1000000 nM
Compound 4: only a limit was reported (the forecaster's own chance of this, stated with the estimate: 25%); at least 20-fold (1.30 log units) between middle value and limit.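

In this assay compound 4 gives > 1000000 nM, and this is a limit of the assay. At this position the new group gives the largest rises shown: an at least 22-fold higher number from compound 3 to compound 4 (1.35 log units; beyond the scatter), an at least 660-fold higher number from compound 2 to compound 4 (2.82 log units; beyond the scatter) and an at least 160-fold higher number from compound 1 to compound 4 (2.22 log units; beyond the scatter). Compound 2 and compound 4 both carry a five-membered aromatic ring here, so ring size alone does not set the number.

On these data alone, how far compound 4 lies past its limit remains open. As far as these compounds go, what a plain thiophen-2-yl or a methyl ester in place of the carboxylic acid would give also remains open.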